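Swapping the tetrazole substituent: from pyridin-2-yl to an ester

The compounds below may be only part of what the source reports. "The series", "measured", "known", "first", "only" and "open" are said of these compounds alone.

Three compounds share one core, an octyl-bearing phenoxy chain linked through a ketone to a tetrazole, and differ only in the group on the tetrazole carbon. Compound 1 `CCCCCCCCc1ccc(OCC(=O)Cn2nnnc2-c2ccccc2Cl)cc1` gives 4600 nM in an assay on microsomes from brain for inhibition of Fatty-acid amide hydrolase 1 (Rattus norvegicus), read by fluorescence and HPLC, with a stated time of 60 min (on this read-out lower numbers stand for stronger inhibition and higher numbers for weaker inhibition), compound 2 `CCCCCCCCc1ccc(OCC(=O)Cn2nnnc2-c2cccnc2)cc1` gives 190 nM and compound 3 `CCCCCCCCc1ccc(OCC(=O)Cn2nnnc2-c2ccccn2)cc1` gives 880 nM. Compound 3 stands second highest of the three, with a 4.6-fold higher number from compound 2 to compound 3 (0.67 log units; beyond the scatter) and a 5.2-fold lower number from compound 1 to compound 3 (0.72 log units; beyond the scatter). Compound 4 `CCCCCCCCc1ccc(OCC(=O)Cn2nnnc2C(=O)OCC)cc1` makes the change (ethoxycarbonyl in place of pyridin-2-yl on an aromatic carbon). The steps already seen, including a 24-fold lower number from compound 1 to compound 2 (1.38 log units; beyond the scatter), show that this position swings the number by modest to large amounts, so a step beyond the scatter is expected, most likely toward a higher number. Compound 4 is estimated at 2000 nM, between 400 nM and 10000 nM, expected to be a 2.3-fold higher number from compound 3 to compound 4 (0.36 log units; beyond the scatter).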

Compound 4, half-maximal inhibitory concentration: 940 nM
Estimate against measurement, compound 4: 2.1-fold (0.33 log units) above; low and high end bracket the measured number.
By their numbers in this assay, from the lowest: compound 2; then compounds 3 and 4 (each within the scatter of the next); then compound 1.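

In this assay the ethoxycarbonyl group, which has no ring, gives a 1.1-fold higher number from compound 3 to compound 4 (0.03 log units; within the scatter) and so shows that a pyridin-2-yl ring is not required at this position to reach this level. Set against the other two groups, it gives both a 4.9-fold higher number from compound 2 to compound 4 (0.69 log units; beyond the scatter) and a 4.9-fold lower number from compound 1 to compound 4 (0.69 log units; beyond the scatter), so a group without a ring can fall between them. On these data alone, whether a carboxylic acid, an amide or a methyl ester here would give a similar number stays open. Nothing measured here explains these steps.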